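A few compounds are considered here, and "the series" means these few. Any claim that something is new, unique, unknown or untested is made for them only; others in the source may bear on it.

Measured so far:
compound 1 `Cc1cc(C(C)C)nnc1N1CCN(c2ncccn2)CC1` – in a functional assay on BV-2 cells (Mus musculus) for inhibition, read by ELISA, with a stated time of 16 h (on this read-out lower numbers stand for stronger inhibition and higher numbers for weaker inhibition), compound 1 sits at the assay limit, > 100000 nM.
compound 2 `Cc1cc(-c2ccc(C(F)(F)F)cc2)nnc1N1CCN(c2ncccn2)CC1` – in this assay compound 2 gives 37400 nM.
compound 3 `Cc1cc(-c2ccc(F)cc2)nnc1N1CCN(c2ncccn2)CC1` – in this assay compound 3 gives 76300 nM.

Compound 3 carries the higher of the two numbers; the nearest one is set by a 2.0-fold higher number from compound 2 to compound 3 (0.31 log units; beyond the scatter). The other step onto it is an at least 1.3-fold lower number from compound 1 to compound 3 (0.11 log units; that floor lies within the scatter), its floor given by the limit of > 100000 nM in this assay, at which 1 of the 3 values shown sits. Compound 4 `Cc1ccc(-c2cc(C)c(N3CCN(c4ncccn4)CC3)nn2)cc1` differs from compound 3 by methyl in place of fluoro on an aromatic carbon. For the measured compounds named here, no measured step swaps methyl for fluoro; the only change at this position, a 2.0-fold higher number from compound 2 to compound 3 (0.31 log units; beyond the scatter), was modest. A shift within the scatter is therefore expected, a 1.3-fold lower number from compound 3 to compound 4 (0.10 log units; within the scatter). Compound 4 is estimated at 60000 nM, between 25000 nM and 150000 nM in this assay.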

Compound 4, half-maximal inhibitory concentration: 17200 nM
Compound 4: middle estimate off by 3.5-fold (0.54 log units), on the high side, and the stated range ends above it.
By their numbers in this assay, from the lowest: compound 4; then compound 2; then compound 3. At a limit, above all of these: compound 1.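

In this assay, for the compounds shown here, the number at this position does not only rise on moving away from trifluoromethyl: methyl gives the lowest number so far, with a 4.4-fold lower number from compound 3 to compound 4 (0.65 log units; beyond the scatter) and a 2.2-fold lower number from compound 2 to compound 4 (0.34 log units; beyond the scatter). The position therefore tolerates a change in either direction, and the fluoro and trifluoromethyl compounds alone did not show this. Against isopropyl, an at least 5.8-fold lower number from compound 1 to compound 4 (0.76 log units; beyond the scatter) is only a floor, since compound 1 stands at a limit: the limit of > 100000 nM in this assay, at which 1 of the 4 values shown sits.

As far as these compounds go, whether ethyl, methoxy or an amine at this position would lower the number further remains open.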